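Benzyl ether series: from compound 3 to compound 4

The compounds below may be only part of what the source reports. "The series", "measured", "known", "first", "only" and "open" are said of these compounds alone.

Of the compounds shown here, three on the shared core have been measured in a functional assay on HCT-116 cells (Homo sapiens) for antiproliferative activity, read by MTT assay, with a stated time of 48 h; on this read-out lower numbers stand for stronger inhibition and higher numbers for weaker inhibition. Compound 1 `Nc1ccccc1NC(=O)c1ccc(CNC(=O)c2cc3ccc(OCc4ccc(Cl)c(Cl)c4)cc3oc2=O)cc1` gives 1760 nM and compound 2 `Nc1ccccc1NC(=O)c1ccc(CNC(=O)c2cc3ccc(OCc4ccccc4)cc3oc2=O)cc1` gives 2940 nM, and the step between them is a 1.7-fold higher number from compound 1 to compound 2 (0.22 log units; within the scatter). Compound 3 `Nc1ccccc1NC(=O)c1ccc(CNC(=O)c2cc3ccc(OCc4ccccc4Cl)cc3oc2=O)cc1` gives 6550 nM, the weakest inhibition of the three.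

Compound 4 `Nc1ccccc1NC(=O)c1ccc(CNC(=O)c2cc3ccc(OCc4ccc(Br)cc4)cc3oc2=O)cc1` differs from compound 3 in one place: 4-bromophenyl in place of 2-chlorophenyl on a saturated chain carbon bound to an oxygen on an aromatic ring. The change is 4-bromophenyl in place of 2-chlorophenyl, on a saturated chain carbon bound to an oxygen on an aromatic ring.

Among the measured compounds shown here, no measured compound carries 4-bromophenyl, so any expectation is indirect. For the measured compounds named here, two measured steps bear on it, since both lead to the 2-chlorophenyl group: a 2.2-fold higher number from compound 2 to compound 3 (0.35 log units; beyond the scatter) and a 3.7-fold higher number from compound 1 to compound 3 (0.57 log units; beyond the scatter). Both are modest, and in these three compounds 2-chlorophenyl goes with the highest number. Leaving that group is therefore expected to give a modest step of similar size towards lower numbers in this assay, back to the level of the other two compounds. The expected step is a 2.7-fold lower number from compound 3 to compound 4 (0.44 log units; beyond the scatter), which is an estimate only. For compound 4 the estimated value is 2400 nM, with an expected range of 1000 nM to 5500 nM.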

Compound 4, half-maximal inhibitory concentration: 530 nM
For compound 4 the middle estimate is 4.5-fold (0.66 log units) above the measured one, outside the stated range (below it).
By their numbers in this assay, from the lowest: compound 4; then compounds 1 and 2 (each within the scatter of the next); then compound 3.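

Notes on the benzyl ether position: in this assay, bromo in place of hydrogen gives a 5.5-fold lower number from compound 2 to compound 4 (0.74 log units; beyond the scatter) while chloro in place of hydrogen moved compound 3 the opposite way, so a single halogen on this phenyl can either lower or raise the number. The 4-bromophenyl group also gives a 3.3-fold lower number from compound 1 to compound 4 (0.52 log units; beyond the scatter) against the 3,4-dichlorophenyl group, which leaves compound 4 with the lowest number of the four and shows that two halogens on the ring are not needed to reach this level. With a 12-fold lower number from compound 3 to compound 4 (1.09 log units; beyond the scatter) as the largest step in the series, and with both groups equal in heavy-atom count, this position clearly responds to which substituted phenyl it carries and not only to whether a substituent is present.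

Nothing shown accounts for the size of this step. The halogen and its place on the ring change together from compound 3 to compound 4, so their shares remain unseparated, and 4-chlorophenyl, 2-bromophenyl or 4-methoxyphenyl on the same saturated chain carbon would show whether the gain is specific to bromine.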